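The source may hold more compounds than are shown below. What is called first, only, known or untested is meant among the compounds shown, and "the series" means these compounds.

In a functional assay on MV4-11 cells (Homo sapiens) for inhibition, read by resazurin assay, with a stated time of 72 h (a higher number here means a weaker inhibitor of growth, a lower number a stronger inhibitor of growth), three compounds have been measured:

Compound 1, `O=C1NCCC12CCN(c1c(Cl)cncc1-c1ccco1)CC2`, gives 940 nM.
Compound 2, `O=C1NCCC12CCN(c1c(Cl)cncc1-c1cccs1)CC2`, gives 480 nM.
Compound 3, `O=C1NCCC12CCN(c1c(Cl)cncc1-c1ccsc1)CC2`, gives 190 nM.

Compound 1 has the highest number of the three. The step of a 2.0-fold lower number from compound 1 to compound 2 (0.29 log units; within the scatter) stays within the scatter, whereas a 4.9-fold lower number from compound 1 to compound 3 (0.69 log units; beyond the scatter) and a 2.5-fold lower number from compound 2 to compound 3 (0.40 log units; beyond the scatter) go beyond it, so compound 3 is the strongest growth inhibitor of the three.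

Compound 4, `O=Cc1ccc(-c2cncc(Cl)c2N2CCC3(CCNC3=O)CC2)o1`, keeps the furan-2-yl ring of compound 1 and differs from it in one place: formyl in place of hydrogen on an aromatic carbon. None of the three measured steps bears directly on this change: each of them swaps one five-membered ring for another, while the step from compound 1 to compound 4 adds a group to a ring that is kept. Among the compounds with values here, with no measured example of a substituent on the five-membered ring, there is no basis to expect a step beyond the scatter in either direction in this assay. Close to compound 1 is therefore where compound 4 is estimated to sit, at 900 nM, with a range from 300 nM to 2700 nM. This estimate means the step of a 1.0-fold lower number from compound 1 to compound 4 (0.02 log units; within the scatter) is expected to stay within the scatter, and the wide range reflects that nothing measured here speaks to a formyl group.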

Compound 4, concentration for 50% growth inhibition: 5190 nM
Estimate against measurement, compound 4: 5.8-fold (0.76 log units) below; measured number above the stated range.
By their numbers in this assay, from the lowest: compound 3; then compounds 2 and 1 (each within the scatter of the next); then compound 4.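

Within the data shown here, until this point only the five-membered ring itself had been exchanged; compound 4 is the first case of a group added to that ring, and in this assay formyl in place of hydrogen, next to the ring oxygen, gives a 5.5-fold higher number from compound 1 to compound 4 (0.74 log units; beyond the scatter). This ring carbon is therefore not indifferent to substitution: this small addition moves the number beyond the scatter towards weaker growth inhibition, and the distance to the thiophene compounds is greater, with an 11-fold higher number from compound 2 to compound 4 (1.03 log units; beyond the scatter) and a 27-fold higher number from compound 3 to compound 4 (1.44 log units; beyond the scatter). Nothing available here explains this weakening.

The compounds shown carry only one substituent on the ring, so they cannot tell whether the weakening belongs to formyl itself or would follow any group at this place, and a methyl, a hydroxymethyl, an amine or a carboxylic acid on the same carbon would help separate the two. Going by these compounds, it also remains open whether a formyl group on the thiophen-3-yl ring of compound 3 would bring a step of similar size.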